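The source may report more compounds than this note shows. Statements on the series, on what has been measured and on what is new or still open speak of the compounds shown alone.

Series notes. Two members of the series have been measured in a functional assay on MKN-74 cells (Homo sapiens) for antiproliferative activity, with a stated time of 24 h; a higher number here means a weaker inhibitor, a lower number a stronger inhibitor. Compound 2, `Cc1ccc(C(=O)Nc2sc3c(c2C(N)=O)CCN(C(=S)Nc2ccccc2Cl)C3)cc1`, gives 11300 nM in this assay. Compound 1, `NC(=O)c1c(NC(=O)c2ccccc2Cl)sc2c1CCN(C(=O)Nc1ccccc1Cl)C2`, gives 16300 nM in this assay. The two numbers lie within the usual scatter of one another, so on the data so far compound 2 and compound 1 cannot be told apart, and neither can be called the stronger inhibitor; both sit in a weak range. Compound 1 and compound 2 differ in more than one place, so no single structural step can be read from that pair.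

The next compound, compound 3, `Cc1ccc(C(=O)Nc2sc3c(c2C(N)=O)CCN(C(=O)Nc2ccccc2Cl)C3)cc1`, is the direct partner of compound 2: a group of 10 heavy atoms (7 carbon, 1 nitrogen, 1 oxygen, 1 chlorine; one six-membered aromatic ring of carbon only) in place of a group of 10 heavy atoms (7 carbon, 1 nitrogen, 1 sulfur, 1 chlorine; one six-membered aromatic ring of carbon only), on an amine nitrogen in a ring. For the measured compounds named here, no measured pair isolates this change, so there is no precedent for its size. With nothing to point either way, the expected step from compound 2 to compound 3 in this assay is a 1.2-fold higher number from compound 2 to compound 3 (0.09 log units; within the scatter), that is, no shift beyond the scatter. On that basis compound 3 is estimated at 14000 nM in this assay, with a range from 6000 nM to 35000 nM.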

Compound 3, half-maximal inhibitory concentration: 27600 nM
Compound 3: the middle estimate sits 2.0-fold (0.29 log units) below what was measured; the range from low to high includes it.
By their numbers in this assay, from the lowest: compounds 2, 1 and 3 (each within the scatter of the next, the first and the last beyond it).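

For the compounds shown here, the exchange on the amine nitrogen in a ring gives the first single-place step: a 2.4-fold higher number from compound 2 to compound 3 (0.39 log units; beyond the scatter) in this assay, a modest change in which the sulfur-containing compound 2 holds the lower number, so the exchange of sulfur for oxygen in this group is not silent here. The second single-place step, 4-methylphenyl in place of 2-chlorophenyl on a carbonyl carbon, reads a 1.7-fold higher number from compound 1 to compound 3 (0.23 log units; within the scatter) and gives no order between compound 1 and compound 3, so on this pair that exchange cannot be separated from the scatter. Nothing measured alongside these numbers speaks to the origin of either step.

From the compounds shown here alone, whether the oxygen-to-sulfur exchange gives a step of similar size with 2-chlorophenyl on the carbonyl carbon remains open, since one pair supports no general rule. Also open, going by these compounds, is whether a cyclohexyl group on the urea nitrogen, or a methoxy or nitrile group on the benzoyl ring, would move this series out of its weak range in this cell assay.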